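This account rests on a few compounds, and the source may have more. Where it says the series, first, only, none or still open, it means among the compounds named here.

Compound 1 `Cc1cc(=O)c2c(O)c(CN3CCC(N4CCCCC4)CC3)c(O)c([C@H]3CCN(C)C[C@H]3O)c2o1` gives 31% in a functional assay on Caco-2 cells (Homo sapiens) for inhibition, read by MTT assay, with a stated time of 48 h, tested at 10 uM; on this read-out higher numbers stand for more inhibition of growth at the one concentration tested and lower numbers for less inhibition of growth
Compound 2 `Cc1cc(=O)c2c(O)c(CN3CCCC3)c(O)c([C@H]3CCN(C)C[C@H]3O)c2o1` gives 22% in this assay

Compound 2 at 22% lies within the usual scatter of compound 1 at 31% and so holds no clear rank on these two numbers. Compound 3 `Cc1cc(=O)c2c(O)c(CN(C(C)C)C(C)C)c(O)c([C@H]3CCN(C)C[C@H]3O)c2o1` has not yet been measured. It departs from compound 2 in one place (diisopropylamino in place of pyrrolidin-1-yl on a saturated chain carbon bound to an aromatic carbon), with diisopropylamino in place of pyrrolidin-1-yl on a saturated chain carbon bound to an aromatic carbon. For the measured compounds named here, no measured step shows what this exchange does in this assay on its own. With only the closeness of those two values to go on, no step beyond the scatter is expected, and any direction remains tentative. The estimated step is a number 3 percentage points higher from compound 2 to compound 3 (within the scatter) and stays within the scatter. Compound 3 is expected at 25% with an estimated range from 10% to 40% in this measurement.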

Compound 3, percent growth inhibition at one concentration: 22%
The estimate for compound 3 lay 3 percentage points above the measured number; low and high end bracket the measured number.
By their numbers in this assay, from the lowest: compounds 2, 3 and 1 (each within the scatter of the next).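

In this assay, diisopropylamino in place of pyrrolidin-1-yl on a saturated chain carbon bound to an aromatic carbon gives no change at the digits printed from compound 2 to compound 3 (within the scatter). For the compounds shown here, this is the first exchange at this position that can be read on its own: the ring of pyrrolidin-1-yl gives way to an amine with no ring and more heavy atoms, and the read-out stays within the scatter, so this position tolerates that particular exchange in this assay. The data offer nothing that would explain this outcome.

As far as these compounds go, what a morpholine ring, a primary amine or a carboxylic acid would do on the same carbon remains open. Also open, from the compounds shown here alone, is whether compound 2 and compound 3 would separate at any other concentration, since each has a reading at only one.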